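The compounds below may be only part of what the source reports. "The series", "measured", "known", "first", "only" and "open" are said of these compounds alone.

In an in vitro ADME assay on microsomes from liver (Mus musculus) for pharmacokinetics, read by LC-MS, with a stated time of 10 min, tested at 1 uM (a higher number here means faster removal of the compound, a lower number slower removal), compound 1 (`CC(C)NC(=O)[C@H]1CN(C)C[C@@H]1c1ccc(/C=C/C(=O)Nc2ccccc2N)cc1`) gives 12 mL/min/kg and compound 2 (`CC(C)N1C[C@H](C(=O)Nc2ccc(Cl)cc2)[C@@H](c2ccc(/C=C/C(=O)Nc3ccccc3N)cc2)C1`) gives 38 mL/min/kg. Compound 2 therefore holds the higher of the two numbers, and the gap lies beyond the usual scatter. Compound 3 (`CC(C)(CO)N1C[C@H](C(=O)Nc2ccc(Cl)cc2)[C@@H](c2ccc(/C=C/C(=O)Nc3ccccc3N)cc2)C1`) differs from compound 2 in one place: hydroxymethyl in place of hydrogen on a saturated chain carbon bound to an amine nitrogen in a ring and two saturated chain carbons, which turns isopropyl into 1-(hydroxymethyl)-1-methylethyl. Going by the values given here, no measured pair shows the effect of this change, so any forecast is uncertain. A small downward move, within the scatter, is expected, and the estimated change is a 1.4-fold lower number from compound 2 to compound 3 (0.13 log units; within the scatter). Compound 3 is expected at 28 mL/min/kg, with an estimated range of 12 mL/min/kg to 65 mL/min/kg.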

Compound 3, clearance: 40 mL/min/kg
Beside the measured number, compound 3's estimate is 1.4-fold (0.15 log units) below it; the measured number falls inside the stated range.
By their numbers in this assay, from the lowest: compound 1; then compounds 2 and 3 (each within the scatter of the next).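

In this assay, putting hydroxymethyl in place of hydrogen on a saturated chain carbon bound to an amine nitrogen in a ring and two saturated chain carbons gives a 1.1-fold higher number from compound 2 to compound 3 (0.02 log units; within the scatter). In this one pair, then, turning isopropyl into 1-(hydroxymethyl)-1-methylethyl leaves clearance indistinguishable from that of the parent. No measurement shown here accounts for this result. As far as these compounds go, whether a carboxylic acid or an amine on this carbon would read the same stays open, as does whether a longer chain would.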